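The source may report more compounds than this note shows. Statements on the series, on what has been measured and on what is new or still open speak of the compounds shown alone.

Measured so far:
- compound 1 `Nc1ccc(S(=O)(=O)N2CCN(c3ncc(C(O)(C(F)(F)F)C(F)(F)F)cc3C#CC3CC3)CC2)cn1`: < 14 mL.min-1.g-1
- compound 2 `CCn1cc(-c2cc(C(O)(C(F)(F)F)C(F)(F)F)cnc2N2CCN(S(=O)(=O)c3ccc(N)nc3)CC2)cn1`: 20 mL.min-1.g-1

Within the data shown here, in an ADME assay (liver) for metabolic stability, with Liver microsome (Homo sapiens) as the target, using microsomes and NADPH, with a stated time of 30 min, tested at 1 uM (a higher number here means faster removal of the compound, a lower number slower removal), compound 2 gives 20 mL.min-1.g-1, the only true number so far. For compound 1 the entry < 14 mL.min-1.g-1 is a limit of the assay, not a number.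

Compound 3 `Nc1ccc(S(=O)(=O)N2CCN(c3ncc(C(O)(C(F)(F)F)C(F)(F)F)cc3-c3ccoc3)CC2)cn1` places furan-3-yl where compound 2 carries 1-ethyl-1H-pyrazol-4-yl: furan-3-yl in place of 1-ethyl-1H-pyrazol-4-yl on an aromatic carbon. Among the measured compounds shown here, one measured step bears on this, a change on that same aromatic carbon: an at least 1.4-fold higher number from compound 1 to compound 2 (0.15 log units; that floor lies within the scatter). Since that step gives only a floor, within the scatter, no shift beyond the scatter is expected, and the estimated step is a 1.1-fold higher number from compound 2 to compound 3 (0.04 log units; within the scatter). For compound 3 the estimate is 22 mL.min-1.g-1, with an expected range of 14 mL.min-1.g-1 to 45 mL.min-1.g-1.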

Compound 3, intrinsic clearance in microsomes: < 14 mL.min-1.g-1
Compound 3 was reported as a limit (the forecaster's own chance of this, stated with the estimate: 20%); middle value at least 1.5-fold (0.19 log units) from the limit.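

Replacing 1-ethyl-1H-pyrazol-4-yl with furan-3-yl on this aromatic carbon gives an at least 1.4-fold lower number from compound 2 to compound 3 (0.15 log units; that floor lies within the scatter) in this assay. A second five-membered aromatic ring has now been tested at this position, and the floor on this step does not separate it from the first. The step from compound 1 to compound 3 cannot be read, because both compounds are reported only as a limit: the limit of < 14 mL.min-1.g-1 in this assay, at which 2 of the 3 values shown sit.

As far as these compounds go, the true number behind the limit for compound 3 remains unknown. From the compounds shown here alone, it also remains open how an amine or a longer chain on this carbon would read.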